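A Butyl Swap Among Compounds Stuck at a Limit

This account rests on a few compounds, and the source may have more. Where it says the series, first, only, none or still open, it means among the compounds named here.

Three amines on a shared core have yet to give a readable number. In an ADME assay on Caco-2 cells (Homo sapiens) for inhibition, read by sulforhodamine B assay, with a stated time of 72 h (on this read-out lower numbers stand for stronger inhibition and higher numbers for weaker inhibition), compound 1 (`CCCNC(=C\C(=O)/C=C/c1ccc(O)c(OC)c1)/C=C/c1ccc(O)c(OC)c1`), with propyl on the amine nitrogen, gives only a limit (> 25000 nM). Compound 2 (`CCC(C)NC(=C\C(=O)/C=C/c1ccc(O)c(OC)c1)/C=C/c1ccc(O)c(OC)c1`), with sec-butyl there, also gives only a limit (> 25000 nM). Compound 3 (`COc1cc(/C=C/C(=O)/C=C(/C=C/c2ccc(O)c(OC)c2)NC2CCCCC2)ccc1O`), with cyclohexyl, is a limit too (> 25000 nM). Compound 3 therefore has no number of its own and stands with the others: the limit of > 25000 nM in this assay, at which 3 of the 3 values shown sit.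

Compound 4 (`CCCCNC(=C\C(=O)/C=C/c1ccc(O)c(OC)c1)/C=C/c1ccc(O)c(OC)c1`) changes one place of compound 3, with butyl in place of cyclohexyl on an amine nitrogen. The measured steps that bear on this are a step that the two limits leave unreadable from compound 1 to compound 3 and a step that the two limits leave unreadable from compound 2 to compound 3, so these swaps between a chain and cyclohexyl offer no readable size to carry over, and no step beyond the scatter is expected in either direction. The estimated step is a step that the limit leaves unreadable from compound 3 to compound 4 with no firm direction. Compound 4 is estimated at 30000 nM within a range of 15000 nM to 60000 nM and may well come back as a limit again.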

Compound 4, half-maximal inhibitory concentration: > 25000 nM
Compound 4: no number, only a limit (the forecaster's own chance of this, stated with the estimate: 85%); the middle value does not contradict the limit.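

Among the compounds shown here, compound 4 gives only a limit, so no step from compound 1, compound 2 or compound 3 to compound 4 can be read: the limit of > 25000 nM in this assay, at which 4 of the 4 values shown sit. The compounds shown leave open how these amine groups would rank in this assay, since none yet has a readable number.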